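Sulfur oxidation in a hydroxybenzimidazole series: cytotoxicity outlook

The source may report more compounds than this note shows. Statements on the series, on what has been measured and on what is new or still open speak of the compounds shown alone.

Measured compounds:
compound 1, `Cn1c(CSc2ccccc2)nc2c(CN3CCCC3)c(O)ccc21`, 227000 nM
compound 2, `Cc1ccc(SCc2nc3c(Cn4ccnc4)c(O)ccc3n2C)cc1`, 60800 nM
compound 3, `Cc1ccc(SCc2nc3c(Cn4ccnc4C)c(O)ccc3n2C)cc1`, 91200 nM

In an ADME assay on HepG2 2.2.15 cells (Homo sapiens) for cytotoxicity, with a stated time of 9 days (on this read-out lower numbers stand for higher toxicity in this test and higher numbers for lower toxicity in this test), compound 2 gives the lowest number of the three. Its nearest neighbour is compound 3, reached by a 1.5-fold higher number from compound 2 to compound 3 (0.18 log units; within the scatter), a step that stays within the scatter, while compound 1 gives the highest number, beyond the scatter from compound 2.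

The unmeasured compound 4, `Cc1ccc([S+]([O-])Cc2nc3c(Cn4ccnc4)c(O)ccc3n2C)cc1`, differs from compound 2 in one place: a group of 9 heavy atoms (7 carbon, 1 oxygen, 1 sulfur; one six-membered aromatic ring of carbon only) in place of a group of 8 heavy atoms (7 carbon, 1 sulfur; one six-membered aromatic ring of carbon only), on a saturated chain carbon bound to an aromatic carbon. The (4-methylphenyl)sulfanyl group leaves and a group of 9 heavy atoms (7 carbon, 1 oxygen, 1 sulfur) enters on the saturated chain carbon bound to an aromatic carbon.

Within the data shown here, no measured step touches this part of the molecule; the only measured step, a 1.5-fold higher number from compound 2 to compound 3 (0.18 log units; within the scatter), concerns a methyl on an aromatic carbon elsewhere and is within the scatter. On that basis no step beyond the scatter is expected in this assay, and compound 4 is estimated at 80000 nM (range 30000 nM to 250000 nM), an expected step of a 1.3-fold higher number from compound 2 to compound 4 (0.12 log units; within the scatter).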

Compound 4, half-maximal cytotoxic concentration: 758000 nM
Beside the measured number, compound 4's estimate is 9.5-fold (0.98 log units) below it, and the stated range ends below it.
By their numbers in this assay, from the lowest: compounds 2 and 3 (each within the scatter of the next); then compound 1; then compound 4.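

In this assay, the saturated chain carbon bound to an aromatic carbon proves a far more sensitive place than the methyl change elsewhere, which stayed within the scatter: one added oxygen on the sulfur gives a 12-fold higher number from compound 2 to compound 4 (1.10 log units; beyond the scatter) and so points toward lower toxicity in this test. The group keeps its six-membered aromatic ring of carbon only, and its counts of hydrogen-bond donors and acceptors and its net charge are the same on both sides, so these counts do not separate compound 2 from compound 4. No measurement shown here accounts for the size of this step.

The compounds shown leave open whether the same oxygen on sulfur would have a similar effect in compound 3 or compound 1. They also leave open how a sulfonyl group, or an ether oxygen in place of the sulfur, would read in this assay at this place.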